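Swapping fluoro for dimethylamino on a shared core tested against aromatase

The compounds below may be only part of what the source reports. "The series", "measured", "known", "first", "only" and "open" are said of these compounds alone.

Of the compounds shown here, three that share a core have been measured in an assay on isolated protein for inhibition of Aromatase (Homo sapiens), read by fluorescence, using NADPH, with a stated time of 30 min, tested at 50 uM; on this read-out higher numbers stand for more inhibition at the one concentration tested (going by the name of the read-out) and lower numbers for less inhibition. Compound 1, `Fc1ccc(-c2cc3ccccc3[nH]2)cc1`, gives 21.8% in this assay, the second highest of the three numbers. Compound 3, `Cc1ccc2cc(-c3ccccc3)[nH]c2c1`, gives 32.4%, a number beyond the scatter above compound 1. Compound 2, `COc1ccc2ccc(-c3cc4ccccc4[nH]3)cc2c1`, gives 0.07%, far below compound 1 and also beyond the scatter. No two of these compounds differ in only one place, so no single step between measured compounds is available.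

Compound 4, `CN(C)c1ccc(-c2cc3ccccc3[nH]2)cc1`, has not yet been measured. It differs from compound 1 in one place: dimethylamino in place of fluoro on an aromatic carbon. The dimethylamino group is placed on an aromatic carbon of a six-membered aromatic ring of carbon only, para to a group of 9 heavy atoms. Within the data shown here, nothing measured so far bears on this particular exchange, so the account expects a step from compound 1 to compound 4 of a number 0.2 percentage points higher from compound 1 to compound 4 (within the scatter), not clearly beyond the scatter in either direction. Compound 4 is therefore estimated at 22%, within a range from 5% to 42%.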

Compound 4, a percentage reported as inhibition, at one concentration (the size of the read-out at that concentration, not a potency): 0%
Estimate against measurement, compound 4: 22 percentage points above, outside the stated range (below it).
By their numbers in this assay, from the lowest: compounds 4 and 2 (each within the scatter of the next); then compound 1; then compound 3.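

At this position, on an aromatic carbon para to a group of 9 heavy atoms, the group present matters: in this assay, dimethylamino in place of fluoro gives a number 21.8 percentage points lower from compound 1 to compound 4 (beyond the scatter). Among these compounds, this is the first comparison in the set that changes one place alone, so it ties a difference in this read-out to this exchange rather than to a difference between cores. Nothing available explains why the number falls with this exchange.

The compounds shown leave open where a plain amino group, a hydroxyl or a chlorine would fall at this position, and so whether the fall follows dimethylamino specifically or any replacement of fluoro. They also leave open whether the same exchange would give a similar step on another core.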